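Carbamoyl for Cyano on a Weak Parent Compound

The compounds below may be only part of what the source reports. "The series", "measured", "known", "first", "only" and "open" are said of these compounds alone.

Compound 1 `N#Cc1ccc2[nH]c(-c3ccc4[nH]c(-c5ccccc5)nc4c3)nc2c1`: > 25000 nM
Compound 2 `Cc1ccc(-c2nc3cc(-c4nc5cc(C#N)ccc5[nH]4)ccc3[nH]2)cc1`: 570 nM
Compound 3 `N#Cc1ccc2[nH]c(-c3ccc4[nH]c(-c5cccc6ccccc56)nc4c3)nc2c1`: 650 nM

In a functional assay on RPMI 8402 cells (Homo sapiens) for cytotoxicity (a lower number here means a stronger inhibitor, a higher number a weaker inhibitor), compound 1 gives > 25000 nM, which is a limit of the assay rather than a number (the limit of > 25000 nM in this assay, at which 1 of the 3 values shown sits). Compound 2 gives 570 nM and compound 3 gives 650 nM. Both measured steps, an at least 43-fold lower number from compound 1 to compound 2 (1.64 log units; beyond the scatter) and an at least 38-fold lower number from compound 1 to compound 3 (1.58 log units; beyond the scatter), are large, but each alters the phenyl end of the shared core, not the cyano end.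

Compound 4 `NC(=O)c1ccc2[nH]c(-c3ccc4[nH]c(-c5ccccc5)nc4c3)nc2c1` differs from compound 1 by carbamoyl in place of cyano on an aromatic carbon. Going by the values given here, no measured step touches this position, so the three values give no direct guide to it. Compound 4 is therefore expected to stay close to where compound 1 sits, estimated at 20000 nM (range 3000 nM to 100000 nM), an expected step of an at least 1.2-fold lower number from compound 1 to compound 4 (0.09 log units; that floor lies within the scatter).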

Compound 4, half-maximal inhibitory concentration: > 25000 nM
Compound 4 gave a limit, no number; the forecaster's own chance of this, stated with the estimate: 55%; at least 1.2-fold (0.09 log units) between middle value and limit.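

Compound 1 and compound 4 each give only a limit, not a number, so no step between them can be read: the limit of > 25000 nM in this assay, at which 2 of the 4 values shown sit.

The compounds shown leave open what carbamoyl in place of cyano does on a stronger compound, such as compound 2 or compound 3.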